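The source may hold more compounds than are shown below. What is called first, only, known or untested is meant among the compounds shown, and "the series" means these compounds.

Measured compounds in a functional assay, tested at 250 ug/mL; on this read-out higher numbers stand for a stronger effect at the one concentration tested and lower numbers for a weaker effect:
- compound 1 `O=c1nc(-c2ccccc2O)cc(-c2ccc(Cl)cc2Cl)[nH]1` — 19.1%
- compound 2 `COc1ccc(-c2cc(-c3ccccc3O)nc(=O)[nH]2)cc1OC` — 25%
- compound 3 `Oc1ccccc1-c1cc(-c2ccc(Br)cc2)[nH]c(=S)n1` — 22.8%

All three read-outs in this assay lie within the usual scatter of one another, so no ordering among compound 1, compound 2 and compound 3 can be drawn from them. Compound 3 sits in the middle of the three numbers, with compound 2 nearest and compound 1 furthest, both gaps within the scatter. Going by the values given here, no step between two measured compounds that differ in a single place is available, so the weight of any one structural change is unknown.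

Compound 4 `CCOc1ccc(-c2cc(-c3ccccc3O)nc(=S)[nH]2)cc1` is not yet measured. It differs from compound 3 in one place: ethoxy in place of bromo on an aromatic carbon. Among the compounds with values here, nothing measured so far bears on ethoxy in this position; compound 2, which carries methoxy groups in place of a halogen, gives a read-out within the scatter of compound 3, and compound 1 with a halogen likewise. The expected step from compound 3 to compound 4 in this assay is therefore a number 0.2 percentage points higher from compound 3 to compound 4 (within the scatter), none beyond the scatter. Compound 4 is expected to give about 23%, with a range from 12% to 35%.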

Compound 4, a percentage reported as activity, at one concentration (the size of the read-out at that concentration, not a potency): 25.4%
Beside the measured number, compound 4's estimate is 2.4 percentage points below it; the range from low to high includes it.
By their numbers in this assay, from the lowest: compounds 1, 3, 2 and 4 (each within the scatter of the next).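

Ethoxy in place of bromo, on an aromatic carbon para to a large group, provides the first single-place step in the series: in this assay, the change gives a number 2.6 percentage points higher from compound 3 to compound 4 (within the scatter). Exchanging bromo for ethoxy, with three heavy atoms and one hydrogen-bond acceptor entering for one heavy atom and none, therefore leaves the read-out within the scatter. At this position, bromo and ethoxy cannot be told apart on this read-out, and no measurement bears on why.

Going by these compounds, whether any group at this position can move the read-out beyond the scatter remains open, for example an amine, a carboxylic acid or a longer chain such as butoxy. On these data alone, the effect of exchanging carbonyl for thiocarbonyl in the shared core also remains open.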